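Pyrimidinyl Amine in Place of a Pyridinyl Sulfonamide

The compounds below may be only part of what the source reports. "The series", "measured", "known", "first", "only" and "open" are said of these compounds alone.

Compound 1, `COc1ccc(C(=O)N[C@@H](C)Cn2ccc(-c3ccc(C#N)c(Cl)c3)n2)cc1`: > 30000 nM
Compound 2, `C[C@@H](Cn1ccc(-c2ccc(C#N)c(Cl)c2)n1)NS(=O)(=O)c1cccnc1`: > 30000 nM

In an ADME assay on PC-3 cells (Homo sapiens) for cytotoxicity, read by CCK-8 assay, with a stated time of 6 days (a higher number here means a weaker inhibitor, a lower number a stronger inhibitor), compound 1 gives > 30000 nM, which is a limit of the assay and not a number. Compound 2 gives > 30000 nM in this assay, again a limit rather than a measured value. Compound 2 therefore stands at the same place as compound 1: both values sit at the limit of > 30000 nM in this assay, at which 2 of the 2 values shown sit, and neither compound shows any measurable effect within the tested range. Among the compounds with values here, the two share a common core and differ in the group carried on the amine nitrogen, but no step between them has been computed, so the two values show only that both remain beyond the limit.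

Compound 3, `C[C@@H](Cn1ccc(-c2ccc(C#N)c(Cl)c2)n1)Nc1cncnc1`, has not yet been measured in this assay. It differs from compound 2 by pyrimidin-5-yl in place of (pyridin-3-yl)sulfonyl on an amine nitrogen. Within the data shown here, no measured step between the two compounds is available, and the only evidence is that both measured compounds sit at the limit. For the change from compound 2 to compound 3 a step of a number no higher from compound 2 to compound 3 (the limit leaves the size open) is expected, that is, none beyond the scatter. Compound 3 is therefore estimated at 30000 nM, within 10000 nM to 100000 nM, most likely again reported only as a limit.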

Compound 3, half-maximal inhibitory concentration: > 30000 nM
Compound 3 ended at the assay's limit; the forecaster's own chance of this, stated with the estimate: 75%; the middle value lies on the limit itself.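

In this assay, compound 3 gives > 30000 nM, a limit and not a number, so no step can be read from compound 2 to compound 3. All three compounds stand at the same place: the limit of > 30000 nM in this assay, at which 3 of the 3 values shown sit.

The compounds shown leave open whether the group on the amine nitrogen affects the read-out at all.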